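Swapping the dihydroxyphenyl of a naphthyloxy hydrazone for bromophenyl

The source may report more compounds than this note shows. Statements on the series, on what has been measured and on what is new or still open speak of the compounds shown alone.

Three hydrazones sharing a naphthyloxyacetyl core were tested in an ADME assay on MT4 cells (Homo sapiens) for cytotoxicity, read by MTT assay, with a stated time of 4 days; a lower number here means that less compound is tolerated, a higher number that more compound is tolerated. Compound 1 `C/C(=N\NC(=O)COc1cccc2ccccc12)c1ccc(O)cc1O` gives 59.9 ug/mL and stands highest of the three. Compound 3 `O=C(COc1cccc2ccccc12)N/N=C/c1c[nH]c2ccccc12` gives 51.5 ug/mL, a value within the scatter of compound 1. Compound 2 `COc1ccc(/C=N/NC(=O)COc2cccc3ccccc23)cc1O` gives 7.05 ug/mL, well beyond the scatter below compound 1.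

Compound 4 `C/C(=N\NC(=O)COc1cccc2ccccc12)c1ccccc1Br` has not yet been measured in this assay. It differs from compound 1 in one place: 2-bromophenyl in place of 2,4-dihydroxyphenyl on a carbon with a double bond to nitrogen. Going by the values given here, no measured pair shows a change of this kind, so the expectation rests on the general spread seen among the three compounds. The author expects the step of a 3.0-fold lower number from compound 1 to compound 4 (0.48 log units; beyond the scatter) to be downward and larger than the scatter. For compound 4 the estimate in this assay is 20 ug/mL, with a range from 6 ug/mL to 60 ug/mL.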

Compound 4, half-maximal cytotoxic concentration: 79.8 ug/mL
Beside the measured number, compound 4's estimate is 4.0-fold (0.60 log units) below it; the whole stated range lies below it.
By their numbers in this assay, from the lowest: compound 2; then compounds 3, 1 and 4 (each within the scatter of the next).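

In this assay, going by these compounds alone, 2-bromophenyl in place of 2,4-dihydroxyphenyl on a carbon with a double bond to nitrogen gives a 1.3-fold higher number from compound 1 to compound 4 (0.12 log units; within the scatter), the first single-place step. This position therefore accepts the change with no step beyond the scatter, even though the hydrogen-bond donors and acceptors counted on the leaving group are absent from the entering one. Nothing shown explains why the number holds.

From the compounds shown here alone, whether an amine or a carboxylic acid at this place would also stay within the scatter remains open.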